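This account rests on a few compounds, and the source may have more. Where it says the series, first, only, none or still open, it means among the compounds named here.

Measured compounds in the series:

- compound 1, `COc1ccc(OC)c(N2C(=O)CSC2c2cccc(C(=O)NCCCCc3ccccc3)c2)c1`: 92%
- compound 2, `COc1cccc(OC)c1N1C(=O)CSC1c1cccc(C(=O)NCCCCc2ccccc2)c1`: 80%
- compound 3, `O=C(NCCCCc1ccccc1)c1cccc(C2SCC(=O)N2c2cccc(F)c2)c1`: 92%

All three share one core and one amide side chain; they differ only in the aryl group on the amide-type nitrogen in the ring. In a functional assay on MG-63 cells (Homo sapiens) for inhibition, read by CCK-8 assay, with a stated time of 72 h, tested at 1 uM (on this read-out lower numbers stand for less inhibition and higher numbers for more inhibition at the one concentration tested (going by the name of the read-out)), compound 1 stands level with compound 3 at the digits printed, and together these two give the highest numbers of the three. Among the measured compounds shown here, the only step beyond the scatter is a number 12 percentage points lower from compound 1 to compound 2 (beyond the scatter), and a number 12 percentage points higher from compound 2 to compound 3 (beyond the scatter) mirrors it from the other side. Between compound 1 and compound 3 there is no change at the digits printed from compound 1 to compound 3 (within the scatter).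

Compound 4, `COc1ccc(F)cc1N1C(=O)CSC1c1cccc(C(=O)NCCCCc2ccccc2)c1`, is not yet measured. It differs from compound 1 by fluoro in place of methoxy on an aromatic carbon. For the measured compounds named here, two measured steps bear on this: the replacement of the whole 2,5-dimethoxyphenyl by 3-fluorophenyl left the read-out unchanged, while moving a methoxy to give 2,6-dimethoxyphenyl lowered it by a modest amount. The change to compound 4 is smaller than either, keeping one methoxy and bringing in a fluoro. In this assay compound 4 is therefore expected to stay close to compound 1, with a number 4 percentage points lower from compound 1 to compound 4 (within the scatter) as the expected step, within the scatter. The estimate for compound 4 is 88%, expected between 74% and 97%.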

Compound 4, a percentage reported as inhibition, at one concentration (the size of the read-out at that concentration, not a potency): 86%
For compound 4 the middle estimate is 2 percentage points above the measured one, and the stated range covers the measured number.
By their numbers in this assay, from the lowest: compounds 2, 4, 1 and 3 (each within the scatter of the next, the first and the last beyond it).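

In this assay, the 5-fluoro-2-methoxyphenyl group puts fluoro and methoxy on one ring, and both single changes leading to it can now be read: fluoro in place of methoxy, at the place meta to a large group and para to a methoxy group, gives (a number 6 percentage points lower from compound 1 to compound 4 (within the scatter)), and methoxy in place of hydrogen on the fluoro-bearing ring gives (a number 6 percentage points lower from compound 3 to compound 4 (within the scatter)). Against the 2,6-dimethoxyphenyl group the reading is (a number 6 percentage points higher from compound 2 to compound 4 (within the scatter)), so compound 4 cannot be separated from any of the other three, even though compound 2 and compound 3 differ from each other beyond the scatter. No measurement at hand explains these readings.

The compounds shown leave open whether an amine, a carboxylic acid or a longer alkoxy group at this place would keep the read-out in the same range, or whether only small groups such as fluoro and methoxy do so. With a single tested concentration, they also leave open whether compound 1, compound 3 and compound 4 would separate across a range of concentrations.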